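The source may report more compounds than this note shows. Statements on the series, on what has been measured and on what is new or still open speak of the compounds shown alone.

Measured so far in an assay on cells for inhibition of HSP60/HSP10 (Homo sapiens), with a stated time of 60 min; on this read-out lower numbers stand for stronger inhibition and higher numbers for weaker inhibition:

Compound 1, `N#Cc1ccc(S(=O)(=O)Nc2ccc(-c3nc4cc(NS(=O)(=O)c5ccc(C#N)cc5)ccc4o3)cc2)cc1`: compound 1 gives 49000 nM.
Compound 2, `Cc1ccccc1S(=O)(=O)Nc1ccc2oc(-c3ccccc3)nc2c1`: compound 2 gives only a limit of this assay, > 100000 nM.
Compound 3, `C=Cc1ccc(S(=O)(=O)Nc2ccc(-c3nc4ccccc4o3)cc2)cc1`: compound 3 also gives only a limit, > 100000 nM.

Compound 2 therefore stands at the limit, not at a number, and it shares that position with one other value, as the limit of > 100000 nM in this assay, at which 2 of the 3 values shown sit, records. For the measured compounds named here, the only numbered value in the set, that of compound 1, is itself weak. Compound 4, `COc1ccc(Cl)cc1S(=O)(=O)Nc1ccc2oc(-c3ccccc3)nc2c1`, differs from compound 2 in one place: 5-chloro-2-methoxyphenyl in place of 2-methylphenyl on a sulfonyl sulfur. Going by the values given here, no pair of measured compounds differs in a single place, so no measured step in this assay shows what such an exchange does. With compound 2 at the limit, the expected step that the limit leaves unreadable from compound 2 to compound 4 is none beyond the scatter, with no direction that the data support. Compound 4 is expected to give about 150000 nM, in a range from 40000 nM to 500000 nM, and most probably only a limit again.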

Compound 4, half-maximal inhibitory concentration: > 100000 nM
Compound 4: a limit, no number; the forecaster's own chance of this, stated with the estimate: 75%; the middle value lies beyond the limit too.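

For the compounds shown here, compound 2 and compound 4 both give only a limit in this assay, so no step between them can be read. The compounds shown leave open whether 5-chloro-2-methoxyphenyl in place of 2-methylphenyl on a sulfonyl sulfur changes inhibition in either direction.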